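The source may hold more compounds than are shown below. What is called first, only, known or untested is meant among the compounds shown, and "the series" means these compounds.

Measured so far in a functional assay on MCF7 cells (Homo sapiens) for antiproliferative activity, read by sulforhodamine B assay, with a stated time of 48 h; on this read-out lower numbers stand for stronger inhibition and higher numbers for weaker inhibition:

Compound 1, `CCC(=O)Nc1ccc(S(=O)(=O)Oc2ccccc2C(C)C)cc1`: 11000 nM
Compound 2, `CC(C)c1ccccc1OS(=O)(=O)c1ccc(NC(=O)CCCCl)cc1`: 5200 nM

Compound 2 has the lowest of the two numbers, and compound 1 sits above it; the step of a 2.1-fold lower number from compound 1 to compound 2 (0.33 log units; beyond the scatter) is the only one yet recorded. Compound 3, `CCCNC(=O)Nc1ccc(S(=O)(=O)Oc2ccccc2C(C)C)cc1`, keeps the shared core of compound 2 and changes the group on the carbonyl carbon: propylamino in place of 3-chloropropyl on a carbonyl carbon. In this assay, among the measured compounds shown here, the one recorded step shows that adding a chloromethyl group to the chain of compound 1 brought a modest gain. For the measured compounds named here, compound 3 drops that chlorine again and puts a nitrogen into the chain, which no measured pair covers directly, so the expectation rests loosely on that single step. The change is therefore expected to give back some of the gain, as a step of a 1.7-fold higher number from compound 2 to compound 3 (0.24 log units; within the scatter) that is modest at most. Compound 3 is accordingly estimated at 9000 nM, with a range from 3000 nM to 27000 nM.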

Compound 3, half-maximal inhibitory concentration: 2700 nM
Compound 3: middle estimate off by 3.3-fold (0.52 log units), on the high side; the whole stated range lies above it.
By their numbers in this assay, from the lowest: compounds 3 and 2 (each within the scatter of the next); then compound 1.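

In this assay, propylamino in place of 3-chloropropyl on the carbonyl carbon gives a 1.9-fold lower number from compound 2 to compound 3 (0.28 log units; within the scatter), so among these compounds the chlorine is not required to reach the level of compound 2. Measured against the ethyl group on the same carbonyl carbon, propylamino gives a 4.1-fold lower number from compound 1 to compound 3 (0.61 log units; beyond the scatter), a modest gain in inhibition that shows this position can respond to a change of group. Nothing measured here explains either step.

Compound 3 differs from compound 1 in both the added nitrogen and the longer chain, and the compounds shown cannot separate the two. Butyl on the carbonyl carbon would test the chain without the nitrogen, while butylamino or cyclohexylamino would show how far the group on that nitrogen can grow.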